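The source may report more compounds than this note shows. Statements on the series, on what has been measured and on what is new or still open speak of the compounds shown alone.

Working notes on the series, measured in a functional assay on MCF7 cells (Homo sapiens) for inhibition, read by MTT assay; on this read-out lower numbers stand for stronger inhibition and higher numbers for weaker inhibition.

Of the compounds shown here, three have numbers so far. Compound 1 `O=C(CN1CCC(Cc2ccccc2)CC1)Nc1ccc(C(=O)/C=C/c2cn(Cc3ccc(Br)cc3)nn2)cc1` gives 54500 nM. Compound 2 `CCCCCCCCn1cc(/C=C/C(=O)c2ccc(N)cc2)nn1` gives 31000 nM. Compound 3 `COc1ccccc1N1CCN(CC(=O)Nc2ccc(C(=O)/C=C/c3cn(Cc4ccc(Br)cc4)nn3)cc2)CC1` gives 36800 nM. All three numbers lie within the usual scatter of one another: the gap from compound 3 to compound 2 and the gap from compound 3 to compound 1 are both inside it, so the three compounds cannot be separated on these data, and none can be called more or less potent than another.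

Compound 4 `O=C(CN1CCN(c2ccc([N+](=O)[O-])cc2)CC1)Nc1ccc(C(=O)/C=C/c2cn(Cc3ccc(Br)cc3)nn2)cc1` has not yet been measured. It differs from compound 3 in one place: 4-nitrophenyl in place of 2-methoxyphenyl on an amine nitrogen in a ring. Within the data shown here, no pair of measured compounds shows a step of this kind, so there is no measured step to rest on. The rest of the molecule is kept, and compound 1, with a different group at the same amine nitrogen, gives a number within the scatter of compound 3, so no step beyond the scatter is expected in this assay in either direction.

The number for compound 4 is estimated at 38000 nM, with a range from 15000 nM to 95000 nM. The step from compound 3 to compound 4 that this estimate means is a 1.0-fold higher number from compound 3 to compound 4 (0.01 log units; within the scatter), expected to be none beyond the scatter.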

Compound 4, half-maximal inhibitory concentration: 31600 nM
Estimate against measurement, compound 4: 1.2-fold (0.08 log units) above; low and high end bracket the measured number.
By their numbers in this assay, from the lowest: compounds 2, 4, 3 and 1 (each within the scatter of the next).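

In this assay, among these compounds, 4-nitrophenyl in place of 2-methoxyphenyl on an amine nitrogen in a ring gives a 1.2-fold lower number from compound 3 to compound 4 (0.07 log units; within the scatter) and is the only step so far between compounds that differ in one place. Among the compounds shown here, this pair gives the first direct reading at this position: the two aryl groups differ in what they carry and where they carry it, one having a methoxy group and the other a nitro group, yet the read-out does not separate them. No evidence is available that bears on this step.

On these data alone, it remains open whether any group on this nitrogen can bring a number beyond the scatter of compound 3 in this assay, as only aryl groups have been compared here in a single step. A methyl group or a longer alkyl chain on this nitrogen, or a phenyl group carrying a carboxylic acid or an amine, would show whether the flat response holds beyond these two aryl groups.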